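Removing a Secondary Acetyl Group From a Diterpene Lactone

The compounds below may be only part of what the source reports. "The series", "measured", "known", "first", "only" and "open" are said of these compounds alone.

Compound 1 `C=C1CC[C@@H]2[C@](C)(COC(C)=O)[C@H](OC(C)=O)CC[C@@]2(C)[C@@H]1C/C=C1/C(=O)OC[C@H]1OC(C)=O` gives 1.4 uM in a functional assay on P388 cells (Mus musculus) for cytotoxicity, read by sulforhodamine B assay (a lower number here means that less compound is needed, a higher number that more compound is needed for the effect), the second highest of the three numbers shown. Compound 2 `C=C1CC[C@@H]2[C@](C)(CO[Si](C(C)C)(C(C)C)C(C)C)[C@H](OC(C)=O)CC[C@@]2(C)[C@@H]1C/C=C1/C(=O)OC[C@H]1OC(C)=O` gives 1.41 uM and compound 3 `C=C1CC[C@@H]2[C@](C)(CO)[C@H](OC(C)=O)CC[C@@]2(C)[C@@H]1C/C=C1/C(=O)OC[C@H]1OC(C)=O` gives 0.69 uM. The steps of a 1.0-fold higher number from compound 1 to compound 2 (0.00 log units; within the scatter) and a 2.0-fold lower number from compound 1 to compound 3 (0.31 log units; beyond the scatter) show that a bulkier group changed little, while a free hydroxyl helped modestly. Compound 4 `C=C1CC[C@@H]2[C@](C)(COC(C)=O)[C@H](O)CC[C@@]2(C)[C@@H]1C/C=C1/C(=O)OC[C@H]1OC(C)=O` is made from compound 1 by hydrogen in place of acetyl on an oxygen on a saturated carbon. Among the measured compounds shown here, no measured step touches this oxygen, but the step of a 2.0-fold lower number from compound 2 to compound 3 (0.31 log units; beyond the scatter) likewise replaced a group with hydrogen on an oxygen and gave a modest gain. For compound 4 a small lowering or no change beyond the scatter is therefore expected, a 1.4-fold lower number from compound 1 to compound 4 (0.15 log units; within the scatter). The estimate for compound 4 is 1 uM, between 0.4 uM and 2.5 uM.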

Compound 4, concentration for half-maximal effect: 1.62 uM
For compound 4 the middle estimate is 1.6-fold (0.21 log units) below the measured one; measured number inside the range.
By their numbers in this assay, from the lowest: compound 3; then compounds 1, 2 and 4 (each within the scatter of the next).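

In this assay, acetoxy to hydroxy on this oxygen gives a 1.2-fold higher number from compound 1 to compound 4 (0.06 log units; within the scatter), so at this position the acetyl can be exchanged for hydrogen without a change beyond the scatter. The same exchange on a different oxygen gives a 2.0-fold lower number from compound 1 to compound 3 (0.31 log units; beyond the scatter), so the modest gain seen there does not carry over to this position. Nothing measured here accounts for that contrast.

From the compounds shown here alone, whether an amine or a longer ester chain on this oxygen would move the number remains open. So does the outcome of replacing both of these acetyl groups with hydrogen in one compound.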